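Indole Replaces the Aminomethoxyphenyl Arm of Compound 1

A few compounds are considered here, and "the series" means these few. Any claim that something is new, unique, unknown or untested is made for them only; others in the source may bear on it.

Compound 1 `COc1ccc(-c2c(-c3cc(OC)c(OC)c(OC)c3)c(=O)c2=O)cc1N`: 1.4 nM
Compound 2 `COc1ccc(-c2c(-c3cc(OC)c(OC)c(OC)c3)c(=O)c2=O)c(OC)c1`: 1770 nM
Compound 3 `COc1ccc(-c2c(-c3cc(OC)c(OC)c(OC)c3)c(=O)c2=O)cc1`: 16 nM

In a functional assay on CCRF-CEM cells (Homo sapiens) for inhibition, read by MTT assay, with a stated time of 72 h (a higher number here means a weaker inhibitor, a lower number a stronger inhibitor), compound 1 gives the lowest number of the three, with compound 3 nearest and compound 2 furthest; both gaps lie beyond the scatter. Compound 4 `COc1cc(-c2c(-c3ccc4cc[nH]c4c3)c(=O)c2=O)cc(OC)c1OC` differs from compound 1 in one place on the shared core: 1H-indol-6-yl in place of 3-amino-4-methoxyphenyl on an aromatic carbon. Within the data shown here, two measured steps bear on this exchange. First, an 11-fold higher number from compound 1 to compound 3 (1.06 log units; beyond the scatter), so removing the amino group alone costs a large step. Second, a 110-fold lower number from compound 2 to compound 3 (2.04 log units; beyond the scatter), showing that where a methoxy sits on this arm matters greatly. Among the measured compounds shown here, compound 4 keeps one hydrogen-bond donor in the 1H-indol-6-yl, but the two hydrogen-bond acceptors of the 3-amino-4-methoxyphenyl leave, and no measured pair tests such a wholesale swap. The expectation is therefore a moderate step toward a higher number, a 7.1-fold higher number from compound 1 to compound 4 (0.85 log units; beyond the scatter), staying near compound 3. Compound 4 is estimated at 10 nM, within 2 nM to 60 nM.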

Compound 4, half-maximal inhibitory concentration: 6.6 nM
Compound 4: the middle estimate sits 1.5-fold (0.18 log units) above what was measured; low and high end bracket the measured number.
By their numbers in this assay, from the lowest: compound 1; then compound 4; then compound 3; then compound 2.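

In this assay, replacing the 3-amino-4-methoxyphenyl arm with 1H-indol-6-yl costs only part of what compound 1 achieves, with a 4.7-fold higher number from compound 1 to compound 4 (0.67 log units; beyond the scatter). The same arm improves on 4-methoxyphenyl, with a 2.4-fold lower number from compound 3 to compound 4 (0.38 log units; beyond the scatter), so this position accepts a five-membered aromatic ring joined to a six-membered one, and a methoxy on this arm is not needed for a number between those of compound 1 and compound 3. Nothing available explains the size of either step.

The compounds shown leave open whether an amino group added to the 1H-indol-6-yl arm would close the remaining gap to compound 1. They also leave open whether 1-methyl-1H-indol-6-yl, with a methyl in place of the indole hydrogen, would hold the number of compound 4.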